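Cyclohexyl for dichlorophenyl on the enone chain

The compounds below may be only part of what the source reports. "The series", "measured", "known", "first", "only" and "open" are said of these compounds alone.

Compound 1 `COc1ccc(C(=O)/C(=C/c2ccc(Cl)cc2Cl)CCOC(C)=O)cc1` gives 34800 nM in a functional assay on NB-4 cells (Homo sapiens) for inhibition, read by XTT assay, with a stated time of 48 h; a lower number here means a stronger inhibitor, a higher number a weaker inhibitor. Compound 3 `COc1ccc(C(=O)/C(=C/c2ccc(Cl)cc2Cl)CC(C)OC(C)=O)cc1` gives 36800 nM in this assay, a step of a 1.1-fold higher number from compound 1 to compound 3 (0.02 log units; within the scatter). Compound 2 `COc1ccc(C(=O)/C(=C/C2CCCCC2)CCOC(C)=O)cc1` carries the change (cyclohexyl in place of 2,4-dichlorophenyl on a double-bonded chain carbon bound to a double-bonded chain carbon). In this assay compound 2 reaches only a limit, > 100000 nM, which is the limit of > 100000 nM in this assay, at which 1 of the 3 values shown sits. The step is therefore an at least 2.8-fold higher number from compound 1 to compound 2 (0.45 log units; beyond the scatter). Compound 4 `COc1ccc(C(=O)/C(=C/C2CCCCC2)CC(C)OC(C)=O)cc1`, not yet measured, differs from compound 3 by cyclohexyl in place of 2,4-dichlorophenyl on a double-bonded chain carbon bound to a double-bonded chain carbon, the same change at the same place as the earlier one. The two cores, that of compound 1 and that of compound 3, differ by methyl in place of hydrogen on a saturated chain carbon bound to an oxygen next to a carbonyl group and a saturated chain carbon. The step from compound 3 to compound 4 is expected to be a 3.5-fold higher number from compound 3 to compound 4 (0.55 log units; beyond the scatter), resting on the earlier step of an at least 2.8-fold higher number from compound 1 to compound 2 (0.45 log units; beyond the scatter). Compound 4 is accordingly estimated at 130000 nM, most likely between 60000 nM and 400000 nM, with a limit rather than a number the likeliest outcome.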

Compound 4, half-maximal inhibitory concentration: 33400 nM
The estimate for compound 4 lay 3.9-fold (0.59 log units) above the measured number; the whole stated range lies above it.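

In this assay, cyclohexyl in place of 2,4-dichlorophenyl does not carry over from the core of compound 1 to the core of compound 3, with a 1.1-fold lower number from compound 3 to compound 4 (0.04 log units; within the scatter) set against the earlier step: the same change on two cores in this assay, an at least 2.8-fold higher number (0.45 log units; beyond the scatter) from compound 1 to compound 2 and a 1.1-fold lower number (0.04 log units; within the scatter) from compound 3 to compound 4, at least 3.1-fold (0.50 log units) apart, beyond the scatter of two such steps. Read the other way, the added methyl gives an at least 2.9-fold lower number from compound 2 to compound 4 (0.47 log units; beyond the scatter), so it does not carry over between the two groups either: the same change on two cores in this assay, a 1.1-fold higher number (0.02 log units; within the scatter) from compound 1 to compound 3 and an at least 2.9-fold lower number (0.47 log units; beyond the scatter) from compound 2 to compound 4, at least 3.1-fold (0.50 log units) apart, beyond the scatter of two such steps. The value of compound 2, > 100000 nM, is a limit, so both gaps are bounds only, and these four compounds do not show why the steps differ or how the change runs on any other core.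

Still open, on these data alone, is how a plain phenyl or a longer chain would behave on the double-bonded chain carbon. Also open, as far as these compounds go, is whether an amine or a carboxylic acid in place of the acetyl ester would keep this pattern.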